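The source may hold more compounds than are shown below. What is called first, only, known or untested is meant among the compounds shown, and "the series" means these compounds.

Measured compounds and values:
compound 1, `Cn1cnc2c(Nc3ccc(F)cc3)ncnc21`, 0%
compound 2, `Fc1ccc(Cn2cnc3ncnc(Cl)c32)cc1`, 0%
compound 3, `Nc1ncnc2ncn(Cc3ccc(F)cc3)c12`, 0%

All three were tested in an assay on isolated protein for inhibition of RAC-alpha serine/threonine-protein kinase (Homo sapiens), tested at 30 uM; on this read-out lower numbers stand for less inhibition and higher numbers for more inhibition at the one concentration tested (going by the name of the read-out). Compound 1 gives 0% in this assay, compound 2 gives 0%, and compound 3 gives 0%. Compound 3 therefore stands level with compounds 1 and 2 at the digits shown; none of the three shows inhibition that rises above the scatter of this kind of measurement.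

One step among the measured compounds is a single change on the shared core: from compound 2 to compound 3 the step was no change at the digits printed from compound 2 to compound 3 (within the scatter), with amino in place of chloro on an aromatic carbon. That change moved nothing.

Compound 4, `COc1ncnc2ncn(Cc3ccc(F)cc3)c12`, has not yet been measured. It differs from compound 3 as follows: methoxy in place of amino on an aromatic carbon. Within the data shown here, the step from compound 2 to compound 3, which swapped one small group on the same ring for another without any change in inhibition, is the only measured step that bears on this change, and it gives no reason to expect movement here either.

The estimate for compound 4 is therefore 2%, within -6% to 12%, with an expected step of a number 2 percentage points higher from compound 3 to compound 4 (within the scatter), that is, no change beyond the scatter.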

Compound 4, a percentage reported as inhibition, at one concentration (the size of the read-out at that concentration, not a potency): 0%
For compound 4 the middle estimate is 2 percentage points above the measured one; the range from low to high includes it.
By their numbers in this assay, from the lowest: compounds 1, 2, 3 and 4 (each within the scatter of the next).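

Three different groups have now sat on this aromatic carbon of the shared core, and in this assay methoxy in place of amino gives no change at the digits printed from compound 3 to compound 4 (within the scatter) and methoxy in place of chloro gives no change at the digits printed from compound 2 to compound 4 (within the scatter). Removing the hydrogen-bond donor of the amino group therefore leaves the read-out where it was, but with every compound at the bottom of the scale, these steps show only that none of the three groups brings out inhibition at the one concentration tested, not that the group at this position is unimportant. Nothing measured here explains this flat result.

The compounds shown leave open whether a different group on this carbon, such as a longer alkoxy chain, a benzylamine or a carboxylic acid, would raise inhibition above the scatter. They also leave open whether swapping amino, chloro and methoxy would matter on a related compound that already shows measurable inhibition, since a change can only be seen to lower inhibition where there is some to lose.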